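A few compounds are considered here, and "the series" means these few. Any claim that something is new, unique, unknown or untested is made for them only; others in the source may bear on it.

Compound 1 `CC/C(=C(/c1ccccc1)c1ccc(NC(=O)C(C)C)cc1)c1ccc(OCc2ccccc2)cc1`: > 30000 nM
Compound 2 `CC/C(=C(\c1ccc(NC(=O)C(C)C)cc1)c1ccc(OC)cc1)c1ccc(OCc2ccccc2)cc1`: > 30000 nM

In a functional assay on MCF7 cells (Homo sapiens) for inhibition, read by trypan blue exclusion, with a stated time of 72 h (on this read-out higher numbers stand for weaker inhibition of growth and lower numbers for stronger inhibition of growth), compound 1 gives > 30000 nM, which is a limit and not a number. Compound 2 shares this position, (the limit of > 30000 nM in this assay, at which 2 of the 2 values shown sit). Compound 3 `CC/C(=C(/c1ccccc1)c1ccc(NC(=O)C(C)C)cc1)c1ccc(O)cc1` changes compound 1 at one place: hydrogen in place of benzyl on an oxygen on an aromatic ring. Within the data shown here, the only measured step, a step that the two limits leave unreadable from compound 1 to compound 2, is a different change and gives no size to go on. Any readable result for compound 3 would have to fall on the stronger side of that limit, so a modest gain in inhibition of growth is expected, and only loosely. The expected step is an at least 2.0-fold lower number from compound 1 to compound 3 (0.30 log units; that floor lies within the scatter). For compound 3 the estimated value is 15000 nM, with an expected range of 4000 nM to 40000 nM.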

Compound 3, concentration for 50% growth inhibition: 8500 nM
Beside the measured number, compound 3's estimate is 1.8-fold (0.25 log units) above it, within the range that was stated.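

Swapping the benzyl on this oxygen for hydrogen, which turns benzyloxy into hydroxy, gives an at least 3.5-fold lower number from compound 1 to compound 3 (0.54 log units; beyond the scatter) in this assay. Among the compounds shown, this is the first change that yields a readable growth inhibition, so this position can affect the result. The true size of the step may be larger, since compound 1 stands at a limit and not at a number: the limit of > 30000 nM in this assay, at which 2 of the 3 values shown sit.

Going by these compounds, whether the gain needs the free hydroxy or only the loss of benzyl remains open, as does what a methoxy, an ethoxy or an aminoethoxy chain on that oxygen would give. Also open, on these data alone, is whether the methoxy of compound 2 would alter compound 3.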